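Acyl group exchange at the ring nitrogen: compound 1 to compound 3

The compounds below may be only part of what the source reports. "The series", "measured", "known", "first", "only" and "open" are said of these compounds alone.

Measured so far:
compound 1, `O=C(Nc1cc(C(F)(F)F)cc(C(F)(F)F)c1)C1CCc2ccccc2N1C(=O)c1ccccc1Cl`; in a functional assay on NUGC-3 cells (Homo sapiens) for cytotoxicity, read by sulforhodamine B assay, with a stated time of 72 h (a lower number here means a stronger inhibitor of growth, a higher number a weaker inhibitor of growth), compound 1 gives 1930 nM.
compound 2, `O=C(Nc1ccccc1O)C1CCc2ccccc2N1C(=O)c1ccccc1Cl`; in this assay compound 2 gives 36800 nM.

Compound 1 has the lower of the two numbers; compound 2 sits well above it, a gap beyond the usual scatter. For the measured compounds named here, the two compounds differ in more than one place, so no single step joins them, and only the two values themselves are known.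

Compound 3, `CCCCCCCCC(=O)N1c2ccccc2CCC1C(=O)Nc1cc(C(F)(F)F)cc(C(F)(F)F)c1`, is the next compound for this assay. Relative to compound 1 the change is octyl in place of 2-chlorophenyl on a carbonyl carbon. Going by the values given here, nothing measured so far bears on an exchange of this kind: the acyl group on the ring nitrogen is the same in compound 1 and compound 2, so its contribution is untested. The expected step, a 1.6-fold higher number from compound 1 to compound 3 (0.19 log units; within the scatter), is small and likely within the scatter, with a slight lean toward a higher number. Compound 3 is estimated at 3000 nM, within a range from 800 nM to 12000 nM.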

Compound 3, concentration for 50% growth inhibition: 2230 nM
Estimate against measurement, compound 3: 1.3-fold (0.13 log units) above, and the stated range covers the measured number.
By their numbers in this assay, from the lowest: compounds 1 and 3 (each within the scatter of the next); then compound 2.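

In this assay, the acyl group on the ring nitrogen now has its first direct test: octyl in place of 2-chlorophenyl on a carbonyl carbon gives a 1.2-fold higher number from compound 1 to compound 3 (0.06 log units; within the scatter). In this single pair, with the rest of compound 1 unchanged, a chain with no ring and no chlorine reads the same as the chlorinated aromatic ring within the scatter, so the aromatic ring is not required at this position on this core. No measurement on hand accounts for the two groups reading alike.

It remains open whether the exchange gives the same result with the 2-hydroxyphenyl amide of compound 2, which is shown only with 2-chlorophenyl on this carbonyl carbon. Going by these compounds, a shorter chain such as butyl, or an octyl chain ending in an amine or a carboxylic acid, also remains open here.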